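A sulfo group exchanged for (methylsulfanyl)methyl

The source may report more compounds than this note shows. Statements on the series, on what has been measured and on what is new or still open speak of the compounds shown alone.

Values measured in a functional assay on HepG2 cells (Homo sapiens) for inhibition, read by MTT assay, with a stated time of 3 days (a higher number here means a weaker inhibitor, a lower number a stronger inhibitor), are these:
Compound 1 `CCOC(=O)CN(C)CC(=O)NNC(=O)COc1ccc(-c2nc3ccccc3s2)cc1OC` gives 3180 nM here
Compound 2 `CCOC(=O)[C@H](CS(=O)(=O)O)NCC(=O)NNC(=O)COc1ccc(-c2nc3ccccc3s2)cc1OC` gives 3360 nM here

Compound 2 at 3360 nM stands within the scatter of compound 1 at 3180 nM and has no other measured neighbour. Compound 3 `CCOC(=O)[C@H](CCSC)NCC(=O)NNC(=O)COc1ccc(-c2nc3ccccc3s2)cc1OC` departs from compound 2 by one change, (methylsulfanyl)methyl in place of sulfo on a saturated chain carbon, two bonds along the chain from an amine nitrogen and a carbonyl carbon that is, (methylsulfanyl)methyl in place of sulfo on a saturated chain carbon, two bonds along the chain from an amine nitrogen and a carbonyl carbon.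

For the measured compounds named here, only one measured step bears on this. It altered the same amino substituent, and a 1.1-fold higher number from compound 1 to compound 2 (0.02 log units; within the scatter) is its full size. Going by the values given here, no measured step covers this exact exchange, so the evidence is thin. Resting on that step, no shift beyond the scatter is expected in this assay in either direction. The estimated move is a 1.2-fold lower number from compound 2 to compound 3 (0.06 log units; within the scatter) and no more. For compound 3 the estimated value is 2900 nM with an expected range from 1300 nM to 6300 nM in this assay.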

Compound 3, half-maximal inhibitory concentration: 3330 nM
Beside the measured number, compound 3's estimate is 1.1-fold (0.06 log units) below it, within the range that was stated.
By their numbers in this assay, from the lowest: compounds 1, 3 and 2 (each within the scatter of the next).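

In this assay, the exchange of sulfo for (methylsulfanyl)methyl on a saturated chain carbon, two bonds along the chain from an amine nitrogen and a carbonyl carbon, amounts to a 1.0-fold lower number from compound 2 to compound 3 (0.00 log units; within the scatter), so removing the sulfo group and its hydrogen-bond donor left the number within the scatter. The wider change, (1-(ethoxycarbonyl)-3-(methylsulfanyl)propyl)amino in place of ((ethoxycarbonyl)methyl)(methyl)amino, amounts to a 1.0-fold higher number from compound 1 to compound 3 (0.02 log units; within the scatter), which places all three compounds within the scatter of one another. Nothing available accounts for this flat result.

On these data alone, whether a primary amine or a longer chain at this place, or a carboxylic acid in place of the ethyl ester, would move the number beyond the scatter stays open. The compounds shown also cannot tell whether this amino substituent influences this assay at all.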